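The compounds below may be only part of what the source reports. "The series", "measured", "known", "first", "only" and "open" are said of these compounds alone.

Compound 1 has the structure `COc1nc(-c2ccccc2F)ccc1[C@@H](c1ccccc1)[C@@](O)(CCN(C)C)c1cccc2ccccc12` and compound 2 the structure `COc1nc(-c2ccc(F)cc2)ccc1[C@@H](c1ccccc1)[C@@](O)(CCN(C)C)c1cccc2ccccc12`. In a toxicity assay on Vero cells (Chlorocebus sabaeus) for cytotoxicity (a lower number here means that less compound is tolerated, a higher number that more compound is tolerated), compound 1 gives > 50 ug/mL, which is a limit of the assay rather than a number. In this assay compound 2 likewise gives > 50 ug/mL, again a limit of the assay and not a number. Within the data shown here, the only measured step, a step that the two limits leave unreadable from compound 1 to compound 2, therefore cannot be sized, and compound 2 stands at the same limit as compound 1, as the observation the limit of > 50 ug/mL in this assay, at which 2 of the 2 values shown sit, records.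

Compound 3 has the structure `COc1nc(-c2ccc(C(F)(F)F)cc2)ccc1[C@@H](c1ccccc1)[C@@](O)(CCN(C)C)c1cccc2ccccc12`. Its difference from compound 2 is trifluoromethyl in place of fluoro on an aromatic carbon. Among the measured compounds shown here, no measured step shows what a trifluoromethyl group does here; the one step recorded, from compound 1 to compound 2, sits entirely between two limits. The expectation rests only on the fact that both known values are limits. Compound 3 is therefore expected to remain at or near the limit in this assay, an expected step of a number no higher from compound 2 to compound 3 (the limit leaves the size open). For compound 3 the estimated value in this assay is 50 ug/mL, with a range from 20 ug/mL to 100 ug/mL.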

Compound 3, half-maximal cytotoxic concentration: > 50 ug/mL
Compound 3 gave a limit, no number; the forecaster's own chance of this, stated with the estimate: 65%; the middle value lies on the limit itself.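

In this assay compound 3 gives > 50 ug/mL, which is a limit of the assay and not a number. No step among compound 1, compound 2 and compound 3 can therefore be read, as all three share one limit: the limit of > 50 ug/mL in this assay, at which 3 of the 3 values shown sit.

The compounds shown leave open how much compound the cells tolerate in each case, and whether either change of group makes any difference.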